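Lipophilicity notes on the oxime ether series

This account rests on a few compounds, and the source may have more. Where it says the series, first, only, none or still open, it means among the compounds named here.

Measured compounds:
- compound 1 `CCO/N=C/c1c(N)ncnc1Oc1ccc(NC(=O)C2(C(=O)Nc3ccc(F)cc3)CC2)cc1F`: 3.41
- compound 2 `C#CCO/N=C/c1c(N)ncnc1Oc1ccc(NC(=O)C2(C(=O)Nc3ccc(F)cc3)CC2)cc1F`: 3.34
- compound 3 `Nc1ncnc(Oc2ccc(NC(=O)C3(C(=O)Nc4ccc(F)cc4)CC3)cc2F)c1/C=N/OCCCN1CCCC1`: 3.82

In a physicochemical assay for lipophilicity, using the shake flask method (on this read-out higher numbers stand for higher lipophilicity and lower numbers for lower lipophilicity), compound 2 gives 3.34, the lowest of the three numbers. Compound 1 sits within the scatter of it, since a number 0.07 log units lower from compound 1 to compound 2 (within the scatter). Compound 3 lies clearly above it: a number 0.48 log units higher from compound 2 to compound 3 (beyond the scatter), and likewise a number 0.41 log units higher from compound 1 to compound 3 (beyond the scatter).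

Compound 4 `Nc1ncnc(Oc2ccc(NC(=O)C3(C(=O)Nc4ccc(F)cc4)CC3)cc2F)c1/C=N/OC1CCCC1` differs from compound 2 at the oxygen that carries a double-bonded nitrogen: cyclopentyl in place of propargyl on an oxygen. The two steps that touch the same oxygen are the ones that bear on it. The exchange of ethynyl for methyl on the chain bound to that oxygen left the read-out unchanged within the scatter, whereas the entry of 2-(pyrrolidin-1-yl)ethyl in place of ethynyl raised it by a modest amount. For the measured compounds named here, no measured step puts a five-membered non-aromatic carbon ring at this oxygen, so the direction is taken from these two steps only, and a rise beyond the scatter is expected, somewhat larger than that seen from compound 2 to compound 3.

Compound 4 is therefore estimated at 4.3 in this assay, with a range of 3.8 to 4.9. This corresponds to an expected step of a number 0.96 log units higher from compound 2 to compound 4 (beyond the scatter).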

Compound 4, partition coefficient: 4.27
For compound 4 the middle estimate is 0.03 log units above the measured one, and the stated range covers the measured number.
By their numbers in this assay, from the lowest: compounds 2 and 1 (each within the scatter of the next); then compound 3; then compound 4.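

In this assay, cyclopentyl on the oxygen whose other neighbour is a double-bonded nitrogen stands above every other group in the series: the change from propargyl gives a number 0.93 log units higher from compound 2 to compound 4 (beyond the scatter), and the change from ethyl gives a number 0.86 log units higher from compound 1 to compound 4 (beyond the scatter). For the compounds shown here, the two open chains that lay within the scatter of each other therefore both fall well short of this ring, so the position can move the read-out further than the earlier compounds showed. The step from the chain that ends in pyrrolidine is also upward (a number 0.45 log units higher from compound 3 to compound 4 (beyond the scatter)), so among the compounds shown the highest number belongs to the only group with a ring of carbon only bound to this oxygen, not to the chain carrying the basic-free name of 3-(pyrrolidin-1-yl)propyl.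

As far as these compounds go, whether the ring itself or simply the carbon count sets this level remains open, and an open pentyl chain, a cyclohexyl ring or a tetrahydropyranyl ring at this oxygen would help to separate the two. No measurement in hand accounts for the order of these groups.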